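A few compounds are considered here, and "the series" means these few. Any claim that something is new, unique, unknown or untested is made for them only; others in the source may bear on it.

Measured in an ADME assay on CHO cells (Cricetulus griseus) for cytotoxicity, read by MTT assay; on this read-out higher numbers stand for lower toxicity in this test and lower numbers for higher toxicity in this test:
Compound 1 `Fc1ccc(-c2nc3c(N4CCNCC4)nccc3[nH]2)cc1F`: 8100 nM
Compound 2 `Fc1ccc(-c2nc3c(N4CCN5CCCC5C4)nccc3[nH]2)cc1F`: 32000 nM
Compound 3 `Fc1ccc(-c2nc3c(N4CCCN(CC5CC5)CC4)nccc3[nH]2)cc1F`: 17000 nM

Compound 1 has the lowest number of the three. Compound 3, at 17000 nM, stands nearest to it and compound 2, at 32000 nM, furthest, and both gaps lie beyond the usual scatter.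

The next compound, compound 4 `NC1CCN(c2nccc3[nH]c(-c4ccc(F)c(F)c4)nc23)CC1`, keeps the core of compound 1 and differs from it in one place: 4-aminopiperidin-1-yl in place of piperazin-1-yl on an aromatic carbon. In words, 4-aminopiperidin-1-yl stands in place of piperazin-1-yl on an aromatic carbon. For the measured compounds named here, no two measured compounds differ in a single place, so the data offer no direct guide to this exchange. Only the spread of values in this assay remains to lean on, and in that spread compound 1, at 8100 nM, lies at the low end. A small upward move, possibly none beyond the scatter, is therefore expected, and the estimated step is a 1.5-fold higher number from compound 1 to compound 4 (0.17 log units; within the scatter). For compound 4 the estimated value is 12000 nM, with an expected range from 4500 nM to 32000 nM.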

Compound 4, half-maximal cytotoxic concentration: 8200 nM
Compound 4: middle estimate off by 1.5-fold (0.17 log units), on the high side; measured number inside the range.
By their numbers in this assay, from the lowest: compounds 1 and 4 (each within the scatter of the next); then compounds 3 and 2 (each within the scatter of the next).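

For the compounds shown here, this is the first exchange at this position that can be read on its own: in this assay, 4-aminopiperidin-1-yl in place of piperazin-1-yl on the aromatic carbon gives a 1.0-fold higher number from compound 1 to compound 4 (0.01 log units; within the scatter). At this place, then, a six-membered non-aromatic ring with 2 hetero atoms and one with 1 hetero atom, both with 1 hydrogen-bond donor and 2 hydrogen-bond acceptors, cannot be told apart on this read-out. No supporting measurement bears on why the two compounds read alike.

On these data alone, it remains open whether a group with a different ring oxygen, such as morpholin-4-yl, or an open-chain amine at this place would read the same way. The shown compounds also leave open whether the same exchange would read alike with a different substituent on the difluorophenyl ring.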